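From Fluoropyrimidine to Fluorophenyl: Expecting Little Change

This account rests on a few compounds, and the source may have more. Where it says the series, first, only, none or still open, it means among the compounds named here.

Of the compounds shown here, three sharing one core have been tested in a toxicity assay on HepG2 2.2.15 cells (Homo sapiens) for cytotoxicity, read by CellTiter-Glo; a higher number here means that more compound is tolerated, a lower number that less compound is tolerated. There compound 1 `O=C1CC(c2cnco2)CN1c1cnn2c1CN(C(=O)Nc1cc(F)c(F)c(F)c1)C(C1CC1)C2` gives 139000 nM, compound 2 `Cc1cnc(C2CC(=O)N(c3cnn4c3CN(C(=O)Nc3cc(F)c(F)c(F)c3)C(C3CC3)C4)C2)s1` gives 96200 nM, and compound 3 `O=C1CC(c2ncc(F)cn2)CN1c1cnn2c1CN(C(=O)Nc1cc(F)c(F)c(F)c1)C(C1CC1)C2` gives 115000 nM. Compound 3 thus lies within the scatter of both others, and the three numbers cannot be ranked.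

The next compound, compound 4 `O=C1CC(c2ccc(F)cc2)CN1c1cnn2c1CN(C(=O)Nc1cc(F)c(F)c(F)c1)C(C1CC1)C2`, carries 4-fluorophenyl in place of 5-fluoropyrimidin-2-yl on a saturated ring carbon. Three measured exchanges at this same place bear on the change: a 1.4-fold lower number from compound 1 to compound 2 (0.16 log units; within the scatter), a 1.2-fold lower number from compound 1 to compound 3 (0.08 log units; within the scatter) and a 1.2-fold higher number from compound 2 to compound 3 (0.08 log units; within the scatter). Among the measured compounds shown here, none of them goes beyond the scatter, although no tested compound has a ring of carbon only at this place. No step beyond the scatter is therefore expected in this assay. The estimated step is a 1.3-fold lower number from compound 3 to compound 4 (0.11 log units; within the scatter). For compound 4 the expected value is 90000 nM, with an estimated range of 40000 nM to 160000 nM.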

Compound 4, half-maximal cytotoxic concentration: 32100 nM
Compound 4: middle estimate off by 2.8-fold (0.45 log units), on the high side; measured number below the stated range.
By their numbers in this assay, from the lowest: compound 4; then compounds 2, 3 and 1 (each within the scatter of the next).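

In this assay, the three groups with hetero atoms in the ring could not be told apart at this position, but 4-fluorophenyl separates from each of them, with steps beyond the scatter (a 3.6-fold lower number from compound 3 to compound 4 (0.55 log units; beyond the scatter); a 3.0-fold lower number from compound 2 to compound 4 (0.48 log units; beyond the scatter); a 4.3-fold lower number from compound 1 to compound 4 (0.64 log units; beyond the scatter)). The position is therefore not indifferent to the group it carries: the closest exchange, from 5-fluoropyrimidin-2-yl to 4-fluorophenyl, keeps the six-membered aromatic ring and the fluorine, yet less compound is tolerated. No measurement available here accounts for this step.

With only one ring of carbon alone at this place, the compounds shown leave open whether the lower number goes with that ring generally or with this fluorinated ring. An unsubstituted phenyl, a pyridine ring or a 4-methoxyphenyl group at the same carbon would bear on that question.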